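Notes on the chloro group of compound 1

A few compounds are considered here, and "the series" means these few. Any claim that something is new, unique, unknown or untested is made for them only; others in the source may bear on it.

Measured compounds:
compound 1: `CCCn1ccc2cc(-c3cccnc3)cc(Cl)c2c1=O`, 631 nM
compound 2: `CCCn1ccc2cc(-c3cncnc3)cc(Cl)c2c1=O`, 3980 nM
compound 3: `CCCn1ccc2cc(-c3ccc(OCc4cccnc4)nc3)cc(Cl)c2c1=O`, 316 nM

In a functional assay on CHO cells for agonist activity at metabotropic glutamate receptor 2 (Homo sapiens), read by GTPgammaS binding (on this read-out higher numbers stand for an effect only at larger amounts of compound and lower numbers for an effect already at smaller amounts), compound 1 gives 631 nM, the second highest of the three numbers. The nearest number belongs to compound 3, with a 2.0-fold lower number from compound 1 to compound 3 (0.30 log units; within the scatter); the furthest belongs to compound 2, with a 6.3-fold higher number from compound 1 to compound 2 (0.80 log units; beyond the scatter).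

Compound 4, `CCCn1ccc2cc(-c3cccnc3)ccc2c1=O`, differs from compound 1 in one place: hydrogen in place of chloro on an aromatic carbon. Among the measured compounds shown here, both measured steps concern the pyridin-3-yl group and leave the chloro untouched, so no measured step bears on this change. The direction of the step is therefore open; a shift beyond the scatter is possible in either sense, and the range below is set wide.

For compound 4 in this assay the number is expected to be 1300 nM (range 350 nM to 5000 nM), an expected step of a 2.1-fold higher number from compound 1 to compound 4 (0.31 log units; beyond the scatter).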

Compound 4, half-maximal effective concentration: 7940 nM
Compound 4: the middle estimate sits 6.1-fold (0.79 log units) below what was measured, outside the stated range (above it).
By their numbers in this assay, from the lowest: compounds 3 and 1 (each within the scatter of the next); then compounds 2 and 4 (each within the scatter of the next).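

In this assay, among the compounds shown here, the chloro, untouched across the earlier compounds, now proves to matter: hydrogen in its place on this aromatic carbon, meta to a pyridin-3-yl group, gives a 13-fold higher number from compound 1 to compound 4 (1.10 log units; beyond the scatter). The step is a single swap, so it shows only that the chloro outperforms hydrogen here. No evidence on hand bears on the reason for this step.

As far as these compounds go, whether fluoro, bromo, methyl or methoxy on this carbon would match chloro remains open. So does whether the step keeps its size alongside the pyrimidin-5-yl group of compound 2.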